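The compounds below may be only part of what the source reports. "The series", "measured", "known", "first", "only" and "open" are said of these compounds alone.

In a functional assay on MCF7 cells (Homo sapiens) for antiproliferative activity, read by MTT assay, with a stated time of 72 h (on this read-out lower numbers stand for stronger inhibition and higher numbers for weaker inhibition), compound 1 (`COc1ccc(/C=C2/CN(C)/C(=N/c3ccc(C)cc3)S2)cc1`) gives 7600 nM. Among the measured compounds shown here, this is the lower of the two numbers available so far. The other comes from compound 2 (`COc1ccc(/C=C2\S/C(=N\c3cc(C(F)(F)F)cc(C(F)(F)F)c3)N(C)C2=O)cc1`), which gives 77800 nM, and the gap between them lies beyond the usual scatter of repeated measurements. Compound 2 differs from compound 1 in more than one place, so this gap cannot be tied to any single change. For the measured compounds named here, no measured pair here isolates one group.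

The next compound, compound 3 (`COc1ccc(/C=C2/CN(C)/C(=N/c3ccc([N+](=O)[O-])cc3)S2)cc1`), keeps the core of compound 1 and alters a single substituent: nitro in place of methyl on an aromatic carbon. With no single-change comparison to lean on, the expectation in this assay is a small step, with no firm direction and nothing beyond the scatter. The step expected is a 1.3-fold lower number from compound 1 to compound 3 (0.10 log units; within the scatter). The estimated value for compound 3 is 6000 nM, with an expected range from 1500 nM to 25000 nM.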

Compound 3, half-maximal inhibitory concentration: 9800 nM
Compound 3: the middle estimate sits 1.6-fold (0.21 log units) below what was measured; the measured number falls inside the stated range.
By their numbers in this assay, from the lowest: compounds 1 and 3 (each within the scatter of the next); then compound 2.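

Among the compounds shown here, this is the first comparison that isolates a single change. In this assay, nitro in place of methyl on an aromatic carbon, para to a large group, gives a 1.3-fold higher number from compound 1 to compound 3 (0.11 log units; within the scatter), so this read-out does not separate the two groups at this position, even though nitro has more heavy atoms and brings hydrogen-bond acceptors that methyl lacks. No measurement shown here offers an explanation for this result.

The compounds shown leave open whether this flat result would extend to quite different groups at the same position, such as an amine or a carboxylic acid, since two substituents cannot establish a trend. They also leave open which of the several differences between compound 1 and compound 2 accounts for the gap between those two compounds, and a compound changed in only one of those places would be needed to begin to settle that.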